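A 4-(trifluoromethyl)phenyl amide after a limit value

The source may hold more compounds than are shown below. What is called first, only, known or untested is meant among the compounds shown, and "the series" means these compounds.

Measured in a functional assay on HepG2 cells (Homo sapiens) for antiproliferative activity, read by MTT assay, with a stated time of 24 h; on this read-out higher numbers stand for weaker inhibition and lower numbers for stronger inhibition:
- Compound 1 `COC(=O)c1scc(-c2ccc(NC(=O)c3ccccn3)cc2)c1OC`: 10300 nM
- Compound 2 `COC(=O)c1scc(-c2ccc(NC(=O)c3ccc(OC)nc3)cc2)c1OC`: > 50000 nM (a limit, not a number)

For compound 2 there is no number, only a limit: > 50000 nM. Its standing is therefore only bounded, as the limit of > 50000 nM in this assay, at which 1 of the 2 values shown sits.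

In compound 3 `COC(=O)c1scc(-c2ccc(NC(=O)c3ccc(C(F)(F)F)cc3)cc2)c1OC`, 4-(trifluoromethyl)phenyl stands in place of 6-methoxypyridin-3-yl on a carbonyl carbon (4-(trifluoromethyl)phenyl in place of 6-methoxypyridin-3-yl on a carbonyl carbon). The shared core stays the same. Among the measured compounds shown here, only one measured step changes the group at this place, an at least 4.8-fold higher number from compound 1 to compound 2 (0.68 log units; beyond the scatter), and it lies beyond the scatter. For the measured compounds named here, it shows that this assay responds to a change here, but no measured compound carries the entering group, so its direction for compound 3 is not given directly. Compound 1 gives 10300 nM, so a measurable number is possible with this core. A modest move toward stronger inhibition is expected, although the reading may again stop at the limit. The expected step is an at least 2.0-fold lower number from compound 2 to compound 3 (0.30 log units; that floor lies within the scatter). For compound 3 the estimated value is 25000 nM, with an expected range from 8000 nM to 50000 nM.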

Compound 3, half-maximal inhibitory concentration: 24600 nM
Estimate against measurement, compound 3: 1.0-fold (0.01 log units) above; the measured number falls inside the stated range.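

In this assay, compound 3 shows that an amide carrying a six-membered aromatic ring of carbon only can give a measured number at this place on the carbonyl carbon, with an at least 2.0-fold lower number from compound 2 to compound 3 (0.30 log units; that floor lies within the scatter). The size of that step remains a floor, because its starting point is a limit and not a number: the limit of > 50000 nM in this assay, at which 1 of the 3 values shown sits. The comparison with the pyridin-2-yl group adds a step that can be read in full, a 2.4-fold higher number from compound 1 to compound 3 (0.38 log units; beyond the scatter), so compound 1 keeps the lowest number of the three and the 4-(trifluoromethyl)phenyl group does not match it.

The change from compound 2 to compound 3 replaces the ring nitrogen and the methoxy group with carbon and trifluoromethyl in a single move, so the compounds shown cannot tell which part of it matters, and a plain phenyl group would be needed to separate them. Nor do they show how this place responds to a group of another kind, such as an amine or a carboxylic acid on the ring, or whether any group here can reach a lower number than the pyridin-2-yl group of compound 1.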